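Notes on the group at the saturated ring carbon

This account rests on a few compounds, and the source may have more. Where it says the series, first, only, none or still open, it means among the compounds named here.

Of the compounds shown here, two carry numbers so far. In a functional assay on SW-620 cells (Homo sapiens) for antiproliferative activity, with a stated time of 48 h (a higher number here means that more compound is tolerated, a lower number that less compound is tolerated), compound 1 `Cc1cc(O)c(C2=NN(c3ccc(S(N)(=O)=O)cc3)C(c3ccccc3O)C2)cc1Cl` gives 7350 nM, while compound 2 `Cc1cc(O)c(C2=NN(c3ccc(S(N)(=O)=O)cc3)C(/C=C/c3ccccc3)C2)cc1Cl` gives 84000 nM. Among the compounds with values here, the one measured step, an 11-fold higher number from compound 1 to compound 2 (1.06 log units; beyond the scatter), leaves compound 2 as the highest of the two numbers, with compound 1 its only neighbour. Compound 3 `COc1ccc(C2CC(c3cc(Cl)c(C)cc3O)=NN2c2ccc(S(N)(=O)=O)cc2)cc1OC` is unmeasured; it differs from compound 2 by 3,4-dimethoxyphenyl in place of 2-phenylethenyl on a saturated ring carbon. The step from compound 1 to compound 2 bears on this change: it also exchanged the group on the same saturated ring carbon and was large. Compound 3 reverses the move away from a directly attached aromatic ring, though the hydroxy group of compound 1 is not restored. For compound 3 the expected step is a 5.6-fold lower number from compound 2 to compound 3 (0.75 log units; beyond the scatter), short of a full return to the number of compound 1. Compound 3 is estimated at 15000 nM, with a range of 4000 nM to 60000 nM.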

Compound 3, concentration lethal to 50% of the cells: > 100000 nM
Compound 3: only a limit was reported; the forecaster's own chance of this, stated with the estimate: 5%; at least 6.6-fold (0.82 log units) between middle value and limit.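

In this assay compound 3 gives > 100000 nM, which is a limit of the assay and not a number. The step of an at least 1.1-fold higher number from compound 2 to compound 3 (0.07 log units; that floor lies within the scatter) sets no order between these two compounds, as its floor lies within the scatter, and the reading is bounded by the assay: the limit of > 100000 nM in this assay, at which 1 of the 3 values shown sits. The step of an at least 13-fold higher number from compound 1 to compound 3 (1.13 log units; beyond the scatter) is large and beyond the scatter, which shows that an aromatic ring attached directly to the saturated ring carbon does not in itself keep the number near that of compound 1.

The compounds shown leave open how high the number of compound 3 really lies. They also leave open whether the lower number of compound 1 goes with its hydroxy group, a question that a plain phenyl or a 2-methoxyphenyl group at this carbon would bear on.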